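Series notes: benzylamine-type analogues in a cell growth assay

This account rests on a few compounds, and the source may have more. Where it says the series, first, only, none or still open, it means among the compounds named here.

Measured so far:
compound 1 `COc1cc(Oc2cccc(Nc3ccccc3)c2)cc(OC)c1CNCc1ccccc1` — 7490 nM
compound 2 `CNCc1c(OC)cc(Oc2cccc(Nc3ccccc3)c2)cc1OC` — 15000 nM

Compound 1 `COc1cc(Oc2cccc(Nc3ccccc3)c2)cc(OC)c1CNCc1ccccc1` in a functional assay on SW-620 cells (Homo sapiens) for inhibition, read by MTT assay, with a stated time of 72 h (a higher number here means a weaker inhibitor, a lower number a stronger inhibitor), gives 7490 nM. Among the compounds with values here, compound 2 `CNCc1c(OC)cc(Oc2cccc(Nc3ccccc3)c2)cc1OC` in this assay gives 15000 nM, the highest of the two numbers measured so far; the only step to it, a 2.0-fold higher number from compound 1 to compound 2 (0.30 log units; within the scatter), lies within the scatter, so the two compounds are not separated.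

Compound 3 `COc1cc(Oc2cccc(Nc3ccccc3)c2)cc(OC)c1CNCCNC(C)=O` is not yet measured. Its change from compound 2 is acetamidomethyl in place of hydrogen on a saturated chain carbon bound to an amine nitrogen, so the methylamino group becomes a (2-acetamidoethyl)amino group on the shared core. Within the data shown here, only one measured step touches the same carbon, the removal of phenyl from it, a 2.0-fold higher number from compound 1 to compound 2 (0.30 log units; within the scatter), and it stayed within the scatter. Nothing measured tells how an acetamidomethyl group at this carbon behaves. The step is therefore expected to be a 1.3-fold lower number from compound 2 to compound 3 (0.10 log units; within the scatter), not beyond the scatter, with no direction claimed. Compound 3 is estimated at 12000 nM, within 4000 nM to 40000 nM.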

Compound 3, half-maximal inhibitory concentration: 11900 nM
For compound 3 the middle estimate is 1.0-fold (0.00 log units) above the measured one; the range from low to high includes it.
By their numbers in this assay, from the lowest: compounds 1, 3 and 2 (each within the scatter of the next).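

In this assay, acetamidomethyl in place of hydrogen gives a 1.3-fold lower number from compound 2 to compound 3 (0.10 log units; within the scatter) and acetamidomethyl in place of phenyl gives a 1.6-fold higher number from compound 1 to compound 3 (0.20 log units; within the scatter) on the saturated chain carbon bound to an amine nitrogen. Within the data shown here, this position now holds hydrogen, phenyl and a ring-free amide-bearing chain, and compound 1, compound 2 and compound 3 remain unseparated, which the single earlier step could not show for a third kind of group. No outside evidence bears on this result.

From the compounds shown here alone, whether any group at this carbon can produce a step beyond the scatter stays open, for instance a carboxylic acid, a primary amine in place of the acetamide, or a longer chain. All three compounds share one core, so how these changes read on another core cannot be told.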